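Hydroxamate linker length in a phenylurea series on PC-3 cells

A few compounds are considered here, and "the series" means these few. Any claim that something is new, unique, unknown or untested is made for them only; others in the source may bear on it.

Measured so far:
compound 1, `O=C(Nc1ccc2c(c1)CCN2c1ccc(C(=O)NO)cc1)Nc1ccc(Cl)c(C(F)(F)F)c1`: 3800 nM
compound 2, `O=C(CCCCCCC(=O)Nc1ccc(NC(=O)Nc2ccc(Cl)c(C(F)(F)F)c2)cc1)NO`: 4600 nM

Both compounds carry the same chlorinated trifluoromethylphenyl urea and differ in the part that carries the hydroxycarbamoyl group. In a functional assay on PC-3 cells (Homo sapiens) for inhibition, read by sulforhodamine B assay, with a stated time of 48 h (on this read-out lower numbers stand for stronger inhibition and higher numbers for weaker inhibition), compound 1 gives 3800 nM, and in this assay compound 2 gives 4600 nM. The two values lie within the scatter of each other, so neither can be placed ahead of the other; compound 2 stands alongside compound 1 with no separation beyond the usual spread.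

Compound 3, `O=C(CCCCCC(=O)Nc1ccc(NC(=O)Nc2ccc(Cl)c(C(F)(F)F)c2)cc1)NO`, has not been measured. It differs from compound 2 in one place: hydroxycarbamoyl in place of (hydroxycarbamoyl)methyl on a saturated chain carbon, five bonds along the chain from a carbonyl carbon. The hydroxycarbamoyl group thus sits one bond closer to the carbonyl carbon than the (hydroxycarbamoyl)methyl group it replaces. Among the compounds with values here, there is no measured pair in this set that shows the effect of such a change, so the expectation rests on the structural change alone. A modest step toward weaker inhibition is expected in this assay, of a size that could still fall within the scatter, a 1.4-fold higher number from compound 2 to compound 3 (0.15 log units; within the scatter). Compound 3 is accordingly estimated at 6500 nM, with a range from 2500 nM to 16000 nM.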

Compound 3, half-maximal inhibitory concentration: > 10000 nM
Compound 3 was reported as a limit (the forecaster's own chance of this, stated with the estimate: 5%); middle value at least 1.5-fold (0.18 log units) away from the limit.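

In this assay compound 3 gives > 10000 nM, which is a limit of the assay and not a number. Within the data shown here, replacing (hydroxycarbamoyl)methyl with hydroxycarbamoyl on a saturated chain carbon, five bonds along the chain from a carbonyl carbon, gives an at least 2.1-fold higher number from compound 2 to compound 3 (0.33 log units; beyond the scatter), the first single-place step and the first sign that inhibition in this assay is sensitive to the chain at this position. The size of this step is only a lower bound, and its reading rests on one censored value: the limit of > 10000 nM in this assay, at which 1 of the 3 values shown sits.

As far as these compounds go, the true size of the loss remains open, as does whether the trend continues in either direction, with a longer chain than the 3-(hydroxycarbamoyl)propyl-to-4-(hydroxycarbamoyl)butyl range covered here or with a shorter one. The compounds shown also leave open whether a carboxylic acid or a primary amide at the chain end would behave like hydroxycarbamoyl at this position, and whether the step carries over to the core of compound 1.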